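The compounds below may be only part of what the source reports. "The series", "measured", "known", "first", "only" and "open" are said of these compounds alone.

Measured compounds in this set:
compound 1 `O=S(=O)(c1ccc(F)cc1)c1cnc2cc(F)ccc2c1-c1cccc(F)c1` — 0.95 mL/min
compound 2 `O=S(=O)(c1cc(F)cc(F)c1)c1cnc2cc(F)ccc2c1-c1cccc(F)c1` — 0.06 mL/min
compound 3 `COc1ccc(S(=O)(=O)c2cnc3cc(F)ccc3c2-c2cccc(F)c2)cc1` — 2.94 mL/min

All three share one core and differ only in the aryl group carried on the sulfonyl sulfur. In an ADME assay on microsomes from liver (Homo sapiens) for metabolic stability, tested at 2.5 uM (a lower number here means slower removal, a higher number faster removal of the compound), compound 3 gives 2.94 mL/min, the highest of the three numbers; the other two sit beyond the scatter below it, the nearest being compound 1 with 0.95 mL/min and the furthest compound 2 with 0.06 mL/min.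

The next compound, compound 4 `Cc1ccc(S(=O)(=O)c2cnc3cc(F)ccc3c2-c2cccc(F)c2)cc1C`, continues the variation at the same place: 3,4-dimethylphenyl in place of 4-methoxyphenyl on a sulfonyl sulfur.

For the measured compounds named here, three steps bear on this position. The move a 16-fold lower number from compound 1 to compound 2 (1.20 log units; beyond the scatter) was large, the move a 49-fold higher number from compound 2 to compound 3 (1.69 log units; beyond the scatter) larger still in the opposite direction, and the move a 3.1-fold higher number from compound 1 to compound 3 (0.49 log units; beyond the scatter) modest. Going by the values given here, the aryl on the sulfonyl sulfur thus swings this assay over a wide span, yet no measured compound carries a methyl-bearing aryl there, so the direction for compound 4 is uncertain. Given that compound 3 already stands at the top and that the 3,4-dimethylphenyl keeps no acceptor, the expectation for compound 4 is a step of a 1.8-fold lower number from compound 3 to compound 4 (0.26 log units; within the scatter), with the value estimated at 1.6 mL/min and a range of 0.4 mL/min to 6 mL/min.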

Compound 4, intrinsic clearance in a liver preparation (reported as CLH), per the amount of preparation that the assay uses: 3.71 mL/min
Beside the measured number, compound 4's estimate is 2.3-fold (0.37 log units) below it, and the stated range covers the measured number.
By their numbers in this assay, from the lowest: compound 2; then compound 1; then compounds 3 and 4 (each within the scatter of the next).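

In this assay, the 3,4-dimethylphenyl group on the sulfonyl sulfur cannot be told apart from the 4-methoxyphenyl group, with a 1.3-fold higher number from compound 3 to compound 4 (0.10 log units; within the scatter), so an aryl group without the oxygen of the methoxy can match compound 3 at this position. The step of a 3.9-fold higher number from compound 1 to compound 4 (0.59 log units; beyond the scatter) is modest and the step of a 62-fold higher number from compound 2 to compound 4 (1.79 log units; beyond the scatter) is large, so among these four compounds the two aryl groups without fluorine hold the highest numbers, with no compound going against this. No measurement at hand explains these differences.

Open, as far as these compounds go, is whether an aryl group carrying an amine, a carboxylic acid or a longer chain on the sulfonyl sulfur would stay at this level. Also open, from the compounds shown here alone, is whether the low number of compound 2 is specific to the 3,5-difluorophenyl group.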